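This account rests on a few compounds, and the source may have more. Where it says the series, first, only, none or still open, it means among the compounds named here.

The study follows four compounds in which a methyl(propargyl)amino group sits at the end of a saturated chain attached through an oxygen to an aromatic ring. Compound 1 `C#CCN(C)CCCCOc1ccc2c(c1)CCC2=O` and compound 2 `C#CCN(C)CCCCCOc1ccc2c(c1)CCC2=O` share one core, while compound 3 `C#CCN(C)CCCCCOc1ccc2c(c1)CCCC2=O` and compound 4 `C#CCN(C)CCCCCCOc1ccc2c(c1)CCCC2=O` share another; the difference between the two cores is not broken down here. In an assay on BTI cells for inhibition of Amine oxidase [flavin-containing] B (Homo sapiens), read by fluorescence and Amplex Red, with a stated time of 15 min (on this read-out higher numbers stand for weaker inhibition and lower numbers for stronger inhibition), compound 1 gives 366 nM, and compound 2 gives 94.8 nM. The change between them is (methyl(propargyl)amino)methyl in place of methyl(propargyl)amino on a saturated chain carbon, four bonds along the chain from an oxygen on an aromatic ring, and it made a 3.9-fold lower number from compound 1 to compound 2 (0.59 log units; beyond the scatter). Compound 3 gives 46.3 nM in this assay, the lowest of the three numbers. Compound 4 carries the same kind of change relative to compound 3, namely ((methyl(propargyl)amino)methyl in place of methyl(propargyl)amino on a saturated chain carbon, five bonds along the chain from an oxygen on an aromatic ring); the place differs in that it lies five bonds along the chain from the oxygen on the aromatic ring rather than four. The step from compound 3 to compound 4 is expected to be a 1.9-fold lower number from compound 3 to compound 4 (0.27 log units; within the scatter). For the measured compounds named here, that expectation rests on a 3.9-fold lower number from compound 1 to compound 2 (0.59 log units; beyond the scatter); with only one step of this kind measured and the place one bond further out, a somewhat smaller step is expected. Compound 4 is therefore estimated at 25 nM, with a range from 8 nM to 80 nM.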

Compound 4, half-maximal inhibitory concentration: 133 nM
Compound 4: the middle estimate sits 5.3-fold (0.73 log units) below what was measured, outside the stated range (above it).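

On the core of compound 3, putting (methyl(propargyl)amino)methyl in place of methyl(propargyl)amino gave a 2.9-fold higher number from compound 3 to compound 4 (0.46 log units; beyond the scatter) in this assay. Set beside the earlier step, the same change ran in the opposite direction, so the gain seen on the core of compound 1 cannot be carried over to the core of compound 3: the same change on two cores in this assay, a 3.9-fold lower number (0.59 log units; beyond the scatter) from compound 1 to compound 2 and a 2.9-fold higher number (0.46 log units; beyond the scatter) from compound 3 to compound 4, 11-fold (1.04 log units) apart, beyond the scatter of two such steps This does not show whether the core or the place on the chain, five bonds rather than four from the oxygen on the aromatic ring, sets the direction, as the two differ together and each direction rests on a single pair of compounds.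

The compounds shown leave open how the chain of compound 1 would behave on the core of compound 3, and the chain of compound 4 on the core of compound 1, comparisons that would separate the core from the chain. Also open, on these data alone, is whether a still longer chain, or a dimethylamino group in place of methyl(propargyl)amino, would follow either direction.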